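This account rests on a few compounds, and the source may have more. Where it says the series, first, only, none or still open, it means among the compounds named here.

Compound 1, `C[C@H]1CC/C(=N\Nc2ccc(O)cc2)c2ncc(C(=O)O)c(=O)n21`: > 100 umol/kg
Compound 2, `CCOc1ccc(N/N=C2\CCC(C)n3c2ncc(C(=O)O)c3=O)cc1`: > 100 umol/kg

Both measured values are limits of a functional assay on the whole organism for inhibition, with Rattus norvegicus as the target (on this read-out lower numbers stand for an effect already at smaller amounts and higher numbers for an effect only at larger amounts of compound), not numbers. Compound 1 reaches only > 100 umol/kg, a limit. Compound 2 likewise gives only > 100 umol/kg, a limit, so where it stands is known just as the limit of > 100 umol/kg in this assay, at which 2 of the 2 values shown sit. Compound 3, `CCOc1ccc(N/N=C2\CC[C@H](C)n3c2ncc(C(=O)O)c3=O)cc1`, is not yet measured. (the two compounds have the same atoms and bonds; at least one stereo element is drawn with a configuration in one of them and without one in the other: 1 of 2 stereo elements differ; a stereocentre at a saturated ring carbon is drawn without a configuration in compound 2 and S in compound 3). The two share every atom and bond; only the drawing of one stereocentre differs. Among the compounds with values here, no step between measured compounds is known, so the expected step is a step that the limit leaves unreadable from compound 2 to compound 3, none beyond the scatter, and a limit is again the likeliest outcome. Compound 3 is estimated at 150 umol/kg, within 50 umol/kg to 500 umol/kg.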

Compound 3, dose for 50% inhibition: > 100 umol/kg
Compound 3 was reported as a limit (the forecaster's own chance of this, stated with the estimate: 80%); the middle value does not contradict the limit.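

Compound 1, compound 2 and compound 3 all end as limits in this assay, so no step between them can be read: the limit of > 100 umol/kg in this assay, at which 3 of the 3 values shown sit.

The compounds shown leave open how strongly each one acts, and whether the configuration drawn in compound 3 changes that.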